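The compounds below may be only part of what the source reports. "The series", "measured", "known", "first", "only" and "open" are said of these compounds alone.

Among the two numbers so far, compound 2 `CC(=O)c1ccc(OCc2ccccc2F)cc1` stands lowest: in an assay on isolated protein for inhibition of Amine oxidase [flavin-containing] B (Homo sapiens), read by Amplex Red, with a stated time of 15 min (on this read-out lower numbers stand for stronger inhibition and higher numbers for weaker inhibition), compound 2 gives 56.9 nM, while compound 1 `CC(=O)c1ccc(OCc2ccccc2[N+](=O)[O-])cc1` gives 284 nM, and the single measured step is a 5.0-fold lower number from compound 1 to compound 2 (0.70 log units; beyond the scatter). Compound 3 `CC(=O)c1ccc(OCc2ccc(F)cc2F)cc1` differs from compound 2 by fluoro in place of hydrogen on an aromatic carbon. Among the compounds with values here, that step exchanged one group for another; no measured step adds a second fluoro to a ring already carrying one, so the only guide is indirect. For compound 3 in this assay a step of a 1.1-fold higher number from compound 2 to compound 3 (0.02 log units; within the scatter) is therefore expected, which is within the scatter, giving an estimate of 60 nM with a range from 25 nM to 150 nM.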

Compound 3, half-maximal inhibitory concentration: 27.3 nM
Compound 3: middle estimate off by 2.2-fold (0.34 log units), on the high side; low and high end bracket the measured number.
By their numbers in this assay, from the lowest: compound 3; then compound 2; then compound 1.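

In this assay, a fluoro added to an aromatic carbon, meta to a fluoro group and para to a large group, gives a 2.1-fold lower number from compound 2 to compound 3 (0.32 log units; beyond the scatter), so this position takes an added group with a gain rather than a loss. Within the data shown here, the earlier step showed only one group exchanged for another, not what an addition to the ring does. Nothing measured here explains this gain. From the compounds shown here alone, whether a chloro or methoxy group or an amine at this position would do the same remains open, as does whether this fluoro would give the same step without the first fluoro.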